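Swapping the side group on a bromoacrylamide-bearing core

A few compounds are considered here, and "the series" means these few. Any claim that something is new, unique, unknown or untested is made for them only; others in the source may bear on it.

Compound 2 `C=C(Br)C(=O)Nc1cccc(-c2cn3nc(Cc4cccc(OC)c4)sc3n2)c1` gives the lowest of the three numbers in a functional assay on CCRF-CEM cells (Homo sapiens) for inhibition, read by cell counting, with a stated time of 3 days (a lower number here means a stronger inhibitor, a higher number a weaker inhibitor), at 3100 nM. Compound 1 `COc1ccc(-c2nn3cc(-c4cccc(N)c4)nc3s2)cc1OC` gives 14000 nM, and compound 3 `COc1cccc(Cc2nn3cc(-c4cccc(N)c4)nc3s2)c1` gives 40000 nM. Among the compounds with values here, the only measured step, a 13-fold higher number from compound 2 to compound 3 (1.11 log units; beyond the scatter), concerns a different part of the molecule and so does not bear directly on compound 4 `C=C(Br)C(=O)Nc1cccc(-c2cn3nc(-c4ccc(F)cc4)sc3n2)c1`, which differs from compound 2 by 4-fluorophenyl in place of 3-methoxybenzyl on an aromatic carbon. Compounds 1 and 3 show what different groups at that place do within the amine series, and there compound 1 gives the lower number, so a modest step toward a lower number, a 1.7-fold lower number from compound 2 to compound 4 (0.24 log units; within the scatter), is expected. Compound 4 is therefore estimated at 1800 nM, within a range from 500 nM to 6500 nM.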

Compound 4, half-maximal inhibitory concentration: 830 nM
Compound 4: middle estimate off by 2.2-fold (0.34 log units), on the high side, within the range that was stated.
By their numbers in this assay, from the lowest: compound 4; then compound 2; then compound 1; then compound 3.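

Within the bromoacrylamide series, the group on this aromatic carbon changes the result on its own: in this assay, 4-fluorophenyl in place of 3-methoxybenzyl gives a step beyond the scatter (a 3.7-fold lower number from compound 2 to compound 4 (0.57 log units; beyond the scatter)). Nothing shown explains this step. The swap also changes the ring's attachment and its substituent together, and this single step cannot separate the two.

A plain phenyl or a 4-fluorobenzyl group at this place would help separate them. From the compounds shown here alone, whether a small amine or morpholine can take the ring's place also remains open.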